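Aryl thiocarbamate series: acetamido for hydroxy

The source may report more compounds than this note shows. Statements on the series, on what has been measured and on what is new or still open speak of the compounds shown alone.

Measured so far:
compound 1, `CC(=O)Nc1ccc(OC(=S)Nc2ccc(Sc3ccc([N+](=O)[O-])cc3)cc2)cc1`, 5.06
compound 2, `Oc1ccc(OC(=S)Nc2ccc(Sc3ccc(C(F)(F)F)cc3)cc2)cc1`, 6.66

In a physicochemical assay for lipophilicity (on this read-out lower numbers stand for lower lipophilicity and higher numbers for higher lipophilicity), compound 2 gives the higher of the two numbers; compound 1 sits lower by a margin beyond the scatter. Compound 3, `CC(=O)Nc1ccc(OC(=S)Nc2ccc(Sc3ccc(C(F)(F)F)cc3)cc2)cc1`, is not yet measured. It keeps the trifluoromethyl side of compound 2 and changes one group on the other ring: acetamido in place of hydroxy on an aromatic carbon. Among the measured compounds shown here, no step between measured compounds matches this change, so its size is unknown. Hydroxy leaving and acetamido entering is expected to lower the read-out slightly, near the edge of the scatter, as a number 0.36 log units lower from compound 2 to compound 3 (beyond the scatter). For compound 3 the estimate in this assay is 6.3, within 5.8 to 6.8.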

Compound 3, partition coefficient: 5.96
Beside the measured number, compound 3's estimate is 0.34 log units above it; low and high end bracket the measured number.
By their numbers in this assay, from the lowest: compound 1; then compound 3; then compound 2.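

In this assay the change from hydroxy to acetamido on an aromatic carbon now has a size: a number 0.70 log units lower from compound 2 to compound 3 (beyond the scatter) with the trifluoromethyl side unchanged. On the other ring, trifluoromethyl in place of nitro gives a number 0.90 log units higher from compound 1 to compound 3 (beyond the scatter) with the acetamido side unchanged, so each of the two changes can now be read on its own. Nothing on hand gives a reason for either step.

On these data alone, each step rests on a single pair, so whether either size carries over to other partners stays open. Also open, as far as these compounds go, is where an amine or a methoxy group in place of acetamido would fall.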